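A chloropyridine in place of the methylthiazole

The source may report more compounds than this note shows. Statements on the series, on what has been measured and on what is new or still open speak of the compounds shown alone.

Compound 3 `Cc1nc(-c2nc(N)c3cc(Cc4ccccc4)sc3n2)cs1` carries a 2-methyl-1,3-thiazol-4-yl group on the shared core. In a functional assay on CHO-K1 cells for antagonist activity at adenosine receptor A1 (Homo sapiens), read by a beta-galactosidase reporter and cAMP accumulation, with stated times of 15 min and 6 h (on this read-out lower numbers stand for stronger inhibition and higher numbers for weaker inhibition), compound 3 gives 263 nM, the lowest of the two numbers read in that assay. The nearest number belongs to compound 1 `Cc1csc(-c2nc(N)c3cc(C(C)c4ccccc4)sc3n2)n1`, which in this assay gives 1420 nM, and the gap between these two values lies beyond the usual scatter of the measurement. Compound 2 `C=C(c1ccccc1)c1cc2c(N)nc(-c3nc(C)cs3)nc2s1` in this assay gives only a limit, > 594 nM. Going by the values given here, the single step that joins two measured compounds, a step that the limit leaves unreadable from compound 1 to compound 2, is therefore unreadable because of the limit of > 594 nM in this assay, at which 1 of the 3 values shown sits.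

Compound 4 `Nc1nc(-c2cccc(Cl)n2)nc2sc(Cc3ccccc3)cc12` differs from compound 3 in one place: 6-chloropyridin-2-yl in place of 2-methyl-1,3-thiazol-4-yl on an aromatic carbon. Among the compounds with values here, none of the measured compounds varies this position, and the one recorded step concerns a different site and has no readable size. Within the data shown here, there is thus no precedent in these data for the change, and the step of a 1.5-fold higher number from compound 3 to compound 4 (0.18 log units; within the scatter) is expected to stay near the scatter, with a wide range on either side reflecting that absence. Compound 4 is estimated at 400 nM in this assay, with an expected range from 80 nM to 2000 nM.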

Compound 4, inhibition constant: > 1000 nM
Compound 4: no number, only a limit (the forecaster's own chance of this, stated with the estimate: 10%); at least 2.5-fold (0.39 log units) between middle value and limit.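

Until this result, the position on the aromatic carbon between two ring nitrogen atoms had shown no step at all, and the only recorded step concerned a different site. In this assay, 6-chloropyridin-2-yl in place of 2-methyl-1,3-thiazol-4-yl gives an at least 3.8-fold higher number from compound 3 to compound 4 (0.58 log units; beyond the scatter), so the group at this position does affect the read-out, and this exchange moves it towards weaker inhibition. Compound 4 gives only a limit and no number, so the step has a lower bound but no readable full size, because of this value: the limit of > 1000 nM in this assay, at which 1 of the 4 values shown sits.

The change replaces a five-membered ring with a six-membered one, alters the hetero atoms and brings in a chlorine all at once, and the compounds shown do not separate these parts, so a plain pyridin-2-yl without the chlorine or a 6-methylpyridin-2-yl would be needed to tell them apart. Also open, on these data alone, is how this position responds to other groups, such as a plain phenyl or a thiazole carrying an amine in place of the methyl.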